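Halogen swap on the aryl piperazine of an aminothiophene

A few compounds are considered here, and "the series" means these few. Any claim that something is new, unique, unknown or untested is made for them only; others in the source may bear on it.

Compound 2, `Nc1scc(CN2CCN(c3cc(F)ccc3F)CC2)c1C(=O)c1ccc(Cl)cc1`, stands lowest of the two values recorded in a functional assay on CHO cells with adenosine receptor A1 (Homo sapiens) as the target, read by cAMP accumulation and immunoassay, with a stated time of 6 min, tested at 10 uM (on this read-out higher numbers stand for a weaker effect at the one concentration tested and lower numbers for a stronger effect), with a value of -80%. Its nearest neighbour, compound 1, `Nc1scc(CN2CCN(c3ccc([N+](=O)[O-])cc3)CC2)c1C(=O)c1ccc(Cl)cc1`, gives -17% in this assay; the step of a number 63 percentage points lower from compound 1 to compound 2 (beyond the scatter) was large and beyond the scatter. Compound 3, `Nc1scc(CN2CCN(c3cc(Cl)ccc3Cl)CC2)c1C(=O)c1ccc(Cl)cc1`, is not yet measured. It differs from compound 2 in one place: 2,5-dichlorophenyl in place of 2,5-difluorophenyl on an amine nitrogen in a ring. No measured step exchanges one halogen for another on the 2,5-disubstituted phenyl; the only step shown, from compound 1 to compound 2, replaces 4-nitrophenyl and so bears on this change only loosely, showing that the group on the ring nitrogen can move the read-out strongly. Compound 3 is therefore expected to stay close to compound 2, with a step of a number 10 percentage points higher from compound 2 to compound 3 (within the scatter) that need not exceed the scatter. Compound 3 is estimated at -70%, between -95% and -40%.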

Compound 3, a percentage reported as activity, at one concentration (the size of the read-out at that concentration, not a potency): -62%
The estimate for compound 3 lay 8 percentage points below the measured number, and the stated range covers the measured number.
By their numbers in this assay, from the lowest: compound 2; then compound 3; then compound 1.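

In this assay the exchange of 2,5-difluorophenyl for 2,5-dichlorophenyl on the ring nitrogen gives a number 18 percentage points higher from compound 2 to compound 3 (beyond the scatter) and so shows that the read-out at this position responds to the identity of the halogen, though only modestly. Replacing 4-nitrophenyl with 2,5-dichlorophenyl still gives a number 45 percentage points lower from compound 1 to compound 3 (beyond the scatter) as a large step, so the large drop seen with 2,5-difluorophenyl is not confined to that one group. No measured evidence explains either step.

The compounds shown leave open how a 2,5-dibromophenyl or 2,5-dimethoxyphenyl group, or an unsubstituted phenyl, would read at this position. They also leave open whether the difference between the two halogen-bearing compounds would hold at other concentrations, since each value comes from a single concentration.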